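The source may hold more compounds than are shown below. What is called first, only, known or untested is meant among the compounds shown, and "the series" means these compounds.

Measured compounds, all in a functional assay on MCF7 cells (Homo sapiens) for cytotoxicity, read by MTT assay, with a stated time of 24 h, tested at 80 ug/mL; on this read-out lower numbers stand for a weaker effect and higher numbers for a stronger effect at the one concentration tested:

- compound 1 `Cn1c(-c2ccc(NC(=O)CSc3nc4ccccc4o3)cc2)nc(-c2ccccc2)c1-c1ccccc1`: 76.3%
- compound 2 `Cc1ccc2oc(SCC(=O)Nc3ccc(-c4nc(-c5ccccc5)c(-c5ccccc5)n4C)cc3)nc2c1`: 65.1%
- compound 3 `Cn1c(-c2ccc(NC(=O)CN3CCN(Cc4ccccc4)CC3)cc2)nc(-c2ccccc2)c1-c1ccccc1`: 49.5%

Compound 1 and compound 2 share the same core and differ in one place, (methyl in place of hydrogen on an aromatic carbon); this change gives a number 11.2 percentage points lower from compound 1 to compound 2 (beyond the scatter). Compound 3 carries a different side chain on the same core as compound 1; the difference between the two cores is not broken down here. In this assay compound 3 stands lowest of the three, with compound 2 nearest and compound 1 furthest, both of those gaps lying beyond the scatter.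

Compound 4 `Cc1ccc(CN2CCN(CC(=O)Nc3ccc(-c4nc(-c5ccccc5)c(-c5ccccc5)n4C)cc3)CC2)cc1` is not yet measured. It differs from compound 3 by methyl in place of hydrogen on an aromatic carbon. Among the compounds with values here, this is the same kind of change as the one from compound 1 to compound 2, but not the same: there the methyl entered on an aromatic carbon of a six-membered aromatic ring of carbon only, part of a fused or bridged system of two rings, meta to a fused ring and para to a fused ring; here it enters on a six-membered aromatic ring of carbon only, para to a large group.

Within the data shown here, for compound 4 in this assay the expected step is a number 10.5 percentage points lower from compound 3 to compound 4 (beyond the scatter), a drop of about the size seen from compound 1 to compound 2, resting on a number 11.2 percentage points lower from compound 1 to compound 2 (beyond the scatter) being the only measured instance of this kind of change. Compound 4 is thus estimated at 39%, with a range of 24% to 54%.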

Compound 4, a percentage reported as activity, at one concentration (the size of the read-out at that concentration, not a potency): 49.3%
Beside the measured number, compound 4's estimate is 10.3 percentage points below it, and the stated range covers the measured number.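

In this assay, methyl in place of hydrogen on the benzyl group, that is benzyl to 4-methylbenzyl, gives a number 0.2 percentage points lower from compound 3 to compound 4 (within the scatter), so this replacement leaves no readable mark on the core and side chain of compound 3. Set beside the earlier step on the core of compound 1, the result gives no ground for calling the two steps different: the same change on two cores in this assay, a number 11.2 percentage points lower (beyond the scatter) from compound 1 to compound 2 and a number 0.2 percentage points lower (within the scatter) from compound 3 to compound 4, 11 percentage points apart, within the scatter of two such steps. This shows that the two measured steps are compatible with one shared effect of the methyl, but it does not show that the effect transfers reliably from one core to another, since one step lies beyond the scatter, the other lies within it, and two pairs with the methyl on different rings cannot separate a role of the core from a role of the site.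

The compounds shown leave open how a chlorine, a methoxy group or a carboxylic acid would read in place of the methyl on the 4-methylbenzyl group, and whether a longer chain such as ethyl would read differently from methyl. Also open, on these data alone, is whether these compounds would show a stronger or weaker effect at any other concentration: the read-out is taken at one concentration only.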